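Moving the pyrrole attachment point in a small series

A few compounds are considered here, and "the series" means these few. Any claim that something is new, unique, unknown or untested is made for them only; others in the source may bear on it.

Three compounds share one core and differ only in the five-membered aromatic ring attached to it. In a functional assay on CCRF-CEM cells (Homo sapiens) for cytotoxicity, read by XTT assay, with a stated time of 3 days (on this read-out higher numbers stand for weaker inhibition and lower numbers for stronger inhibition), compound 1 (`OC[C@H]1O[C@@H](n2cc(F)c3c(-c4ccco4)ncnc32)[C@H](O)[C@@H]1O`), which carries furan-2-yl, reads 1400 nM and is the weakest of the three. Compound 2 (`OC[C@H]1O[C@@H](n2cc(F)c3c(-c4cccs4)ncnc32)[C@H](O)[C@@H]1O`), with thiophen-2-yl, reads 270 nM on the same scale. Compound 3 (`OC[C@H]1O[C@@H](n2cc(F)c3c(-c4ccc[nH]4)ncnc32)[C@H](O)[C@@H]1O`), with 1H-pyrrol-2-yl, reads 410 nM and so cannot be told apart from compound 2, while both lie clearly under compound 1. The ring swaps give a 5.2-fold lower number from compound 1 to compound 2 (0.71 log units; beyond the scatter) and a 3.4-fold lower number from compound 1 to compound 3 (0.53 log units; beyond the scatter) while a 1.5-fold higher number from compound 2 to compound 3 (0.18 log units; within the scatter) shows no real difference.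

Compound 4 (`OC[C@H]1O[C@@H](n2cc(F)c3c(-c4cc[nH]c4)ncnc32)[C@H](O)[C@@H]1O`) alters only how the ring is attached: 1H-pyrrol-3-yl in place of 1H-pyrrol-2-yl on an aromatic carbon is the whole change, 1H-pyrrol-3-yl in place of 1H-pyrrol-2-yl on an aromatic carbon. Going by the values given here, no measured pair moves an attachment point within one ring, so the ring swaps are only loose guides, and even those were modest at their largest. The expected result is therefore a 1.0-fold lower number from compound 3 to compound 4 (0.01 log units; within the scatter) with no favoured direction and no shift beyond the scatter. The estimate for compound 4 is 400 nM with an expected range from 130 nM to 1200 nM in this assay when it is tested.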

Compound 4, half-maximal inhibitory concentration: 930 nM
Beside the measured number, compound 4's estimate is 2.3-fold (0.37 log units) below it, within the range that was stated.
By their numbers in this assay, from the lowest: compounds 2 and 3 (each within the scatter of the next); then compounds 4 and 1 (each within the scatter of the next).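

In this assay, the same atoms joined differently give a real change: 1H-pyrrol-3-yl in place of 1H-pyrrol-2-yl produces a 2.3-fold higher number from compound 3 to compound 4 (0.36 log units; beyond the scatter). So at this place on the shared core, the number depends on how the five-membered ring is attached as well as on which ring it is, and the ring swaps alone could not show this. The new compound also changes how the earlier groups look: a 3.4-fold higher number from compound 2 to compound 4 (0.54 log units; beyond the scatter) sets it apart from the thiophen-2-yl compound, while a 1.5-fold lower number from compound 1 to compound 4 (0.18 log units; within the scatter) means it cannot be told apart from the furan-2-yl compound, so furan-2-yl no longer stands alone at the high end of the series.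

Nothing available here explains why moving the attachment point shifts the number. On these data alone, it remains open whether thiophen-3-yl or furan-3-yl would differ from their 2-yl partners in the same direction, and how a pyrrole ring carrying a methyl group or an amine, or a six-membered pyridine ring, would read at this place.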